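The source may report more compounds than this note shows. Statements on the series, on what has been measured and on what is new or still open speak of the compounds shown alone.

Measured in a functional assay on K562 cells (Homo sapiens) for cytotoxicity, read by MTT assay, with a stated time of 24 h; on this read-out higher numbers stand for weaker inhibition and lower numbers for stronger inhibition:
- Compound 1 `CC(CC[C@H]1/C(=C/c2ccc([N+](=O)[O-])cc2)CC[C@H]2C(C)(C)CCC[C@]12C)CC(=O)O`: > 200000 nM
- Compound 2 `COc1ccc(/C=C2\CC[C@H]3C(C)(C)CCC[C@]3(C)[C@H]2CCC(C)CC(=O)O)cc1OC`: > 200000 nM
- Compound 3 `CC(CC[C@H]1/C(=C/c2ccc(Cl)cc2)CC[C@H]2C(C)(C)CCC[C@]12C)CC(=O)O`: > 200000 nM

Compound 1 gives > 200000 nM, which is a limit of the assay and not a number. It shares this position with the other two compounds, as the limit of > 200000 nM in this assay, at which 3 of the 3 values shown sit, shows.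

Compound 4 `CC(CC[C@H]1/C(=C/c2ccc(I)cc2)CC[C@H]2C(C)(C)CCC[C@]12C)CC(=O)O` has iodo in place of nitro on an aromatic carbon, a change from 4-nitrophenyl to 4-iodophenyl: iodo in place of nitro on an aromatic carbon.

Among the compounds with values here, the closest precedent is a step that the two limits leave unreadable from compound 1 to compound 3, where chloro takes the place of nitro on an aromatic carbon. The other changes of the aryl group give a step that the two limits leave unreadable from compound 1 to compound 2 and a step that the two limits leave unreadable from compound 2 to compound 3. None of these steps has a size that can be read, so they offer no direction for the new change. The expectation therefore rests on compound 3, with its step that the two limits leave unreadable from compound 1 to compound 3, and no step beyond the scatter is expected in this assay.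

The expected outcome is a number no higher from compound 1 to compound 4 (the limit leaves the size open). For compound 4 the estimate is 200000 nM, with an expected range from 100000 nM to 400000 nM.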

Compound 4, half-maximal inhibitory concentration: 98000 nM
Compound 4: the middle estimate sits 2.0-fold (0.31 log units) above what was measured; measured number outside the range, below it.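

In this assay, compound 4 is the only one of the four compounds to give a number and not a limit, while the other three aryl groups all stay at the limit: the limit of > 200000 nM in this assay, at which 3 of the 4 values shown sit.

Iodo in place of nitro gives an at least 2.0-fold lower number from compound 1 to compound 4 (0.30 log units; that floor lies within the scatter), iodo in place of chloro gives an at least 2.0-fold lower number from compound 3 to compound 4 (0.30 log units; that floor lies within the scatter), and the change from 3,4-dimethoxyphenyl to 4-iodophenyl gives an at least 2.0-fold lower number from compound 2 to compound 4 (0.30 log units; that floor lies within the scatter). Going by these compounds, each of these is a floor only: one end of each step is a limit, so the true size stays unknown.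

The compounds shown leave open whether bromo on the same aromatic carbon would also bring the read-out off the limit. They also leave open how an amide in place of the carboxylic acid would behave alongside the 4-iodophenyl group.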